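This account rests on a few compounds, and the source may have more. Where it says the series, first, only, none or still open, it means among the compounds named here.

Three compounds share one core and differ only in the group joined to a carbonyl carbon on a nitrogen on an aromatic ring whose other neighbours are an aromatic carbon and a saturated chain carbon. Compound 1 `CN(C(=O)CCc1ccccc1)c1ccc2[nH]c(-c3n[nH]c4ccccc34)cc2n1` carries a phenethyl group there, and in a functional assay on HCT-116 cells (Homo sapiens) for antiproliferative activity, read by MTT assay, with a stated time of 72 h (on this read-out lower numbers stand for stronger inhibition and higher numbers for weaker inhibition), compound 1 gives 11200 nM. Compound 2 `CN(C(=O)c1ccc(Cl)cc1)c1ccc2[nH]c(-c3n[nH]c4ccccc34)cc2n1` carries a 4-chlorophenyl group, and in this assay compound 2 gives 3000 nM. Compound 3 `CN(C(=O)c1ccc([N+](=O)[O-])cc1)c1ccc2[nH]c(-c3n[nH]c4ccccc34)cc2n1` carries a 4-nitrophenyl group, and in this assay compound 3 gives 19900 nM. Compound 2 stands lowest of the three: the step of a 3.7-fold lower number from compound 1 to compound 2 (0.57 log units; beyond the scatter) lies beyond the scatter, as does the step of a 6.6-fold higher number from compound 2 to compound 3 (0.82 log units; beyond the scatter), while the step of a 1.8-fold higher number from compound 1 to compound 3 (0.25 log units; within the scatter) stays within it.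

Compound 4 `CN(c1ccc2[nH]c(-c3n[nH]c4ccccc34)cc2n1)S(=O)(=O)c1ccccc1` has not yet been measured. It differs from compound 2 in one place: phenylsulfonyl in place of (4-chlorophenyl)carbonyl on a nitrogen on an aromatic ring. Going by the values given here, no measured step exchanges a carbonyl for a sulfonyl, so the only guide is how far the measured variants spread around compound 2, which they do only modestly and always toward higher numbers. A modest move to a higher number is therefore expected. In this assay compound 4 is expected to give about 8000 nM, with a likely range from 2500 nM to 25000 nM. The expected step is then a 2.7-fold higher number from compound 2 to compound 4 (0.43 log units; beyond the scatter).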

Compound 4, half-maximal inhibitory concentration: 6740 nM
Compound 4: the middle estimate sits 1.2-fold (0.07 log units) above what was measured, and the stated range covers the measured number.
By their numbers in this assay, from the lowest: compound 2; then compounds 4, 1 and 3 (each within the scatter of the next, the first and the last beyond it).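

The position accepts a sulfonyl link as well as a carbonyl link: this assay shows a 2.2-fold higher number from compound 2 to compound 4 (0.35 log units; beyond the scatter) and so a modest loss, with compound 2 still holding the lowest number of the four. Measured against the phenethyl amide, the same sulfonyl compound shows a 1.7-fold lower number from compound 1 to compound 4 (0.22 log units; within the scatter) and so no readable difference, which means that a phenylsulfonyl group and a phenethylcarbonyl group cannot be told apart in this assay. The step from compound 2 also makes two changes at once, replacing the carbonyl with a sulfonyl and losing the chlorine, and nothing here gives a measured reason for the result of either change.

The compounds shown leave open which of those two changes carries the step, a question that a (4-chlorophenyl)sulfonyl group or a plain benzoyl group on the same nitrogen would separate. They also leave open how the position responds to quite different groups, such as a longer chain ending in an amine or a phenyl ring carrying a carboxylic acid.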